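The source may report more compounds than this note shows. Statements on the series, on what has been measured and on what is new or still open speak of the compounds shown alone.

Measured so far:
compound 1, `CC(=O)OCCOn1cnc2c(Cl)nc(N)nc21`: > 500000 nM in a functional assay on MOLT-4 cells (Homo sapiens) for inhibition; on this read-out lower numbers stand for stronger inhibition and higher numbers for weaker inhibition
compound 2, `CC(=O)OC(C)n1cnc2c(Cl)nc(I)nc21`: 12300 nM in this assay

For compound 1 the read-out is only a limit, (the limit of > 500000 nM in this assay, at which 1 of the 2 values shown sits). Compound 2 carries the iodo group and gives a number, 12300 nM. Compound 3, `CC(=O)OCCOn1cnc2c(Cl)nc(I)nc21`, differs from compound 1 by iodo in place of amino on an aromatic carbon. Going by the values given here, no measured step of this kind is at hand, so the expectation rests on compound 2 alone. The step toward stronger inhibition expected here is an at least 16-fold lower number from compound 1 to compound 3 (1.22 log units; beyond the scatter), well beyond the scatter. Compound 3 is estimated at 30000 nM, within 8000 nM to 200000 nM, because compound 2 gives 12300 nM.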

Compound 3, half-maximal inhibitory concentration: 9400 nM
The estimate for compound 3 lay 3.2-fold (0.50 log units) above the measured number; the range from low to high includes it.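

On the aromatic carbon between two ring nitrogen atoms, iodo in place of amino gives an at least 53-fold lower number from compound 1 to compound 3 (1.72 log units; beyond the scatter) in this assay. This is the first step read at this position, and it has only a lower bound, as compound 1 stands at a limit: the limit of > 500000 nM in this assay, at which 1 of the 3 values shown sits.

The compounds shown leave open whether this size of step belongs to iodo alone or would also come with bromo or a methylamino group on the same carbon. As far as these compounds go, how the chloro group contributes on this core also remains open.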